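1-benzofuran-2-yl in place of thiophen-2-yl at the limit

The compounds below may be only part of what the source reports. "The series", "measured", "known", "first", "only" and "open" are said of these compounds alone.

Compound 1 `COc1nc(N)nc2c1c(-c1ccoc1)cn2[C@@H]1O[C@H](CO)[C@@H](O)[C@H]1O` and compound 2 `COc1nc(N)nc2c1c(-c1cccs1)cn2[C@@H]1O[C@H](CO)[C@@H](O)[C@H]1O` share one core and differ only in the group on an aromatic carbon. In a functional assay on HepG2 cells (Homo sapiens) for antiproliferative activity, read by XTT assay, with a stated time of 72 h (a lower number here means a stronger inhibitor, a higher number a weaker inhibitor), compound 1 gives > 20000 nM as a limit of the assay and not a number. In this assay compound 2 gives > 20000 nM as a limit too, so it has no number of its own. Both values shown sit at that limit (the limit of > 20000 nM in this assay, at which 2 of the 2 values shown sit) and neither can be placed against the other. Among the compounds with values here, the one measured step (a step that the two limits leave unreadable from compound 1 to compound 2) has no readable size and gives no direction.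

The change to compound 3 `COc1nc(N)nc2c1c(-c1cc3ccccc3o1)cn2[C@@H]1O[C@H](CO)[C@@H](O)[C@H]1O` is 1-benzofuran-2-yl in place of thiophen-2-yl (1-benzofuran-2-yl in place of thiophen-2-yl on an aromatic carbon) on an aromatic carbon. Within the data shown here, no measured step carries a size over to this change. The expectation rests on compound 2 at > 20000 nM as a limit and on nothing firmer. The expected outcome is no shift beyond the scatter (a step that the limit leaves unreadable from compound 2 to compound 3) with a limit again the likeliest report. In this assay compound 3 is expected at 25000 nM within an estimated range of 10000 nM to 50000 nM for now.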

Compound 3, half-maximal inhibitory concentration: > 20000 nM
Compound 3: a limit, no number; the forecaster's own chance of this, stated with the estimate: 80%; the middle value is on the limit's open side.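

In this assay no new step can be read among compound 1, compound 2 and compound 3, because each gives a limit and not a number: the limit of > 20000 nM in this assay, at which 3 of the 3 values shown sit.

The compounds shown leave open whether any group at this place on the shared core gives a readable value in this assay, and how far furan-3-yl, thiophen-2-yl and 1-benzofuran-2-yl differ there.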